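Ester Chain Lengthening in a Dihydropyridine Pair

The compounds below may be only part of what the source reports. "The series", "measured", "known", "first", "only" and "open" are said of these compounds alone.

Compound 1: `CSc1ncc(C2C(C(=O)OCCCc3ccccc3)=C(C)NC(C)=C2C(=O)OCCCc2ccccc2)n1Nc1ccccc1` gives 3.15 nM in an assay on isolated protein (strain albino) for antagonist activity at Voltage-dependent L-type calcium channel subunit alpha-1C (Cavia porcellus); on this read-out lower numbers stand for stronger inhibition and higher numbers for weaker inhibition.
Compound 2: `CCOC(=O)C1=C(C)NC(C)=C(C(=O)OCc2ccccc2)C1c1cnc(SC)n1Nc1ccccc1` gives 1.86 nM in this assay.

Of the compounds shown here, two carry numbers so far. In this assay compound 2 gives 1.86 nM, the lower of the two values; compound 1 gives 3.15 nM, a difference that stays within the usual scatter, so no order between them can be claimed.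

Compound 3, `CCOC(=O)C1=C(C)NC(C)=C(C(=O)OCCCc2ccccc2)C1c1cnc(SC)n1Nc1ccccc1`, has not yet been measured. It differs from compound 2 by one change: phenethyl in place of phenyl on a saturated chain carbon bound to an oxygen next to a carbonyl group. The rest of the shared core is untouched.

For the measured compounds named here, no measured pair in this set differs by exactly this change, so the size of the step cannot be read off directly. What the data do show is that compound 1, which carries the 3-phenylpropyl ester on both sides, and compound 2 sit close together in this assay. On that basis the step expected from compound 2 to compound 3 in this assay is a 1.3-fold higher number from compound 2 to compound 3 (0.13 log units; within the scatter), that is, nothing beyond the scatter. Compound 3 is accordingly expected to give about 2.5 nM in this assay, with a range from 1 nM to 6.5 nM.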

Compound 3, half-maximal inhibitory concentration: 2.54 nM
Compound 3: middle estimate off by 1.0-fold (0.01 log units), on the low side; low and high end bracket the measured number.
By their numbers in this assay, from the lowest: compounds 2, 3 and 1 (each within the scatter of the next).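

With compound 3 in hand, the swap of phenyl for phenethyl on a saturated chain carbon bound to an oxygen next to a carbonyl group can be read directly in this assay as a 1.4-fold higher number from compound 2 to compound 3 (0.14 log units; within the scatter) and lies within the scatter, so benzyloxycarbonyl and (3-phenylpropoxy)carbonyl cannot be told apart in this pair. The other ester can now be read on its own too: hydrogen in place of benzyl on a saturated chain carbon, two bonds along the chain from an oxygen next to a carbonyl group, gives a 1.2-fold lower number from compound 1 to compound 3 (0.09 log units; within the scatter) and also stays within the scatter. Across these two single-place comparisons, neither change moves the number beyond the scatter, which the earlier pair, differing in two places, could not show.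

The compounds shown leave open whether an ester chain ending in an amine or a carboxylic acid instead of phenyl, or a chain longer than 3-phenylpropyl, would stay equally close in this assay. Nothing in hand gives a reason for these close numbers.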